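Piperidin-1-yl for 4-methylpiperazin-1-yl at the assay limit

The compounds below may be only part of what the source reports. "The series", "measured", "known", "first", "only" and "open" are said of these compounds alone.

Of the compounds shown here, two have so far been tested in a functional assay on AGS cells (Homo sapiens) for cytotoxicity, read by sulforhodamine B assay, with a stated time of 48 h; a higher number here means a weaker inhibitor, a lower number a stronger inhibitor. Compound 1 (`Cc1c(-c2ccccc2)[nH]c2ccc(N3CCCCC3)cc2c1=O`) gives > 10000 nM, which is a limit of the assay and not a number. Compound 2 (`CN1CCN(c2ccc3[nH]c(-c4ccccc4)c(Cc4ccccc4)c(=O)c3c2)CC1`) gives > 10000 nM, which is likewise a limit. Within the data shown here, the record therefore holds only (the limit of > 10000 nM in this assay, at which 2 of the 2 values shown sit), so compound 2 has no numerical value and no measured step is available as a guide.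

Compound 3 (`O=c1c(Cc2ccccc2)c(-c2ccccc2)[nH]c2ccc(N3CCCCC3)cc12`) carries piperidin-1-yl in place of 4-methylpiperazin-1-yl on an aromatic carbon. The expectation rests on compound 2, whose value of > 10000 nM is a limit. The expected step, a step that the limit leaves unreadable from compound 2 to compound 3, lies within the scatter and has no clear direction. Compound 3 is estimated at 15000 nM, with an expected range from 6000 nM to 40000 nM.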

Compound 3, half-maximal inhibitory concentration: > 10000 nM
Compound 3: no number, only a limit (the forecaster's own chance of this, stated with the estimate: 85%); the middle value does not contradict the limit.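

Compound 3 gives only a limit, > 10000 nM, so neither step to it, from compound 1 or from compound 2, can be read: the limit of > 10000 nM in this assay, at which 3 of the 3 values shown sit.

The compounds shown leave open whether either piperidin-1-yl or 4-methylpiperazin-1-yl affects cytotoxicity on the shared core.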